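Working notes: from ethyl to tert-butyl on the series

The source may hold more compounds than are shown below. What is called first, only, known or untested is meant among the compounds shown, and "the series" means these compounds.

Compound 1 `Cc1ccc(Nc2nc(Nc3ccc(N4CCN(C)CC4)cn3)ncc2Cl)cc1`: 4030 nM
Compound 2 `CCc1ccc(Nc2nc(Nc3ccc(N4CCN(C)CC4)cn3)ncc2Cl)cc1`: 5560 nM

In a functional assay on MDA-MB-231 cells (Homo sapiens) for inhibition, read by CCK-8 assay, with a stated time of 48 h (on this read-out lower numbers stand for stronger inhibition of growth and higher numbers for weaker inhibition of growth), compound 2 stands level with compound 1, and the two cannot be ranked. Within the data shown here, the only measured step, a 1.4-fold higher number from compound 1 to compound 2 (0.14 log units; within the scatter), lies within the scatter. Among the measured compounds shown here, that step is methyl in place of hydrogen on a saturated chain carbon bound to an aromatic carbon, and it is the one measurement that bears on the next change.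

That change leads to compound 3 `CN1CCN(c2ccc(Nc3ncc(Cl)c(Nc4ccc(C(C)(C)C)cc4)n3)nc2)CC1`: tert-butyl in place of ethyl on an aromatic carbon. This is tert-butyl in place of ethyl on an aromatic carbon, para to a large group. The same group grows again, this time by more than in the measured step. For the measured compounds named here, no measured compound carries tert-butyl, and a single step within the scatter gives no direction to extend. A shift beyond the scatter in this assay is therefore not expected, though a wide margin is warranted. The expected size of the move is a 1.1-fold higher number from compound 2 to compound 3 (0.03 log units; within the scatter), with no firm direction implied. Compound 3 is estimated at 6000 nM, with an expected range of 2500 nM to 15000 nM.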

Compound 3, concentration for 50% growth inhibition: 16200 nM
Beside the measured number, compound 3's estimate is 2.7-fold (0.43 log units) below it; the measured number lies above the stated range.
By their numbers in this assay, from the lowest: compounds 1 and 2 (each within the scatter of the next); then compound 3.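

In this assay, among these compounds, this position, on an aromatic carbon para to a large group, no longer looks indifferent to what it carries: the change from 4-ethylphenyl to 4-(tert-butyl)phenyl gives the first step beyond the scatter (a 2.9-fold higher number from compound 2 to compound 3 (0.46 log units; beyond the scatter)), whereas the methyl-to-ethyl step stayed within it. Measured from the methyl compound, the same position gives a step of similar standing (a 4.0-fold higher number from compound 1 to compound 3 (0.60 log units; beyond the scatter)), so among these three compounds tert-butyl gives the weakest inhibition of growth, while compound 1 and compound 2 remain level. Nothing available explains why tert-butyl departs from methyl and ethyl.

The three compounds leave open whether the shift follows the branching of the group or simply its carbon count, a question that isopropyl and a longer straight chain such as n-butyl at the same position would address. They also leave open how this position responds to groups outside the alkyl set, such as an amine or a carboxylic acid, and whether any group here gives stronger inhibition of growth than methyl.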